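The source may report more compounds than this note shows. Statements on the series, on what has been measured and on what is new or still open speak of the compounds shown alone.

For the measured compounds named here, only two compounds related to this step have results so far in an ADME assay on L6 cells (Rattus norvegicus) for cytotoxicity; a lower number here means a stronger inhibitor, a higher number a weaker inhibitor. In that test, compound 1 `O=[N+]([O-])c1ncn(CCCNS(=O)(=O)c2cc(C(F)(F)F)ccc2C(F)(F)F)n1` gives 115000 nM, so a very high concentration is needed to reach the half-way point of inhibition. The result for compound 2 `O=[N+]([O-])c1ncn(CCNS(=O)(=O)Cc2ccccc2)n1` is > 321000 nM, which is a limit of the assay and not a number.

Compound 3 `Cn1ccnc1S(=O)(=O)NCCn1cnc([N+](=O)[O-])n1` has not been measured yet. It carries 1-methyl-1H-imidazol-2-yl in place of benzyl on a sulfonyl sulfur, and the counted difference is 1-methyl-1H-imidazol-2-yl in place of benzyl on a sulfonyl sulfur. Going by the values given here, no measured pair of compounds shows what a swap of this kind does, so the expectation rests on very little. Among the compounds with values here, with compound 1 at 115000 nM as the only exact number, compound 3 is also expected to be a weak inhibitor in this assay. Its result may well be reported as a limit too. The expected change, an at least 1.1-fold lower number from compound 2 to compound 3 (0.05 log units; that floor lies within the scatter), is no step beyond the scatter. For compound 3 the estimated value is 280000 nM, with an expected range from 120000 nM to 450000 nM.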

Compound 3, half-maximal inhibitory concentration: > 332000 nM
Compound 3 gave a limit, no number; the forecaster's own chance of this, stated with the estimate: 60%; middle value at least 1.1-fold (0.07 log units) away from the limit.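

In this assay, compound 2 and compound 3 each give only a limit of the assay and not a number, and no step can be read between them. As far as these compounds go, what 1-methyl-1H-imidazol-2-yl in place of benzyl on a sulfonyl sulfur does to the half-maximal inhibitory concentration remains open, in size and in direction.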